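Chloro in Place of Methoxy: Compound 3 to Compound 4

The compounds below may be only part of what the source reports. "The series", "measured", "known", "first", "only" and "open" are said of these compounds alone.

In a functional assay on the whole organism (strain Swiss) with Mus musculus as the target, in the maximal electroshock model, with a stated time of 0.25 h, at a dose of 300 mg/kg by the intraperitoneal route (on this read-out higher numbers stand for a stronger effect at the one dose given and lower numbers for a weaker effect), three compounds have been measured. Compound 2 `CC(C(=O)N1CCN(c2ccccc2C(F)(F)F)CC1)N1C(=O)CCC1=O` gives 100%. Compound 1 `CCC(C(=O)N1CCN(c2cccc(Cl)c2)CC1)N1C(=O)CCC1=O` gives 75%. Compound 3 `COc1cccc(N2CCN(C(=O)C(C)N3C(=O)CCC3=O)CC2)c1` gives 75%, level with compound 1 at the digits shown and together with it the lowest of the three numbers, while compound 2 stands higher by a margin beyond the scatter. Compound 4 `CC(C(=O)N1CCN(c2cccc(Cl)c2)CC1)N1C(=O)CCC1=O` has not yet been measured. It differs from compound 3 by chloro in place of methoxy on an aromatic carbon. Among the compounds with values here, no measured pair isolates this change; the same 3-chlorophenyl appears in compound 1, which in this assay gives 75%. The expected step is a number 5 percentage points higher from compound 3 to compound 4 (within the scatter), a change within the scatter rather than beyond it. Compound 4 is estimated at 80%, with a range from 55% to 100%.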

Compound 4, a percentage reported as activity, at one dose (the size of the read-out at that dose, not a potency): 75%
The estimate for compound 4 lay 5 percentage points above the measured number; the range from low to high includes it.
By their numbers in this assay, from the lowest: compounds 1, 3 and 4 (each within the scatter of the next); then compound 2.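

In this assay, chloro in place of methoxy on an aromatic carbon gives no change at the digits printed from compound 3 to compound 4 (within the scatter), so 3-methoxyphenyl and 3-chlorophenyl are not told apart at this place. Hydrogen in place of methyl on the saturated chain carbon gives no change at the digits printed from compound 1 to compound 4 (within the scatter), so that chain carbon is not told apart by this change either. Nothing available bears on the reason for either result. Still open, going by these compounds, is whether an amine or a carboxylic acid on the same aromatic carbon, or a longer chain on the saturated carbon, would read differently.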